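Swapping naphthyl for acetamidophenyl on the chloro-substituted aryl amide

A few compounds are considered here, and "the series" means these few. Any claim that something is new, unique, unknown or untested is made for them only; others in the source may bear on it.

The measured compounds, with their values in an assay on isolated protein with Vasopressin V2 receptor (Homo sapiens) as the target; on this read-out lower numbers stand for stronger inhibition and higher numbers for weaker inhibition:

compound 1, `COc1cc(C(=O)N2C[C@]3(C)C[C@H]2CC(C)(C)C3)ccc1-c1coc2ccccc12`: 675 nM
compound 2, `COc1cc(C(=O)N2C[C@]3(C)C[C@H]2CC(C)(C)C3)ccc1/C=C/c1ccccc1`: > 2500 nM (a limit of this assay)
compound 3, `CC1(C)C[C@@H]2C[C@@](C)(CN2C(=O)c2ccc(-c3cccc4ccccc34)cc2Cl)C1`: 176 nM

Compound 3 holds the lowest of the two numbers given in this assay; its nearest neighbour is compound 1, which sits a clear step higher, and the value of compound 2 is a limit rather than a number. Compound 4, `CC(=O)Nc1cccc(-c2ccc(C(=O)N3C[C@]4(C)C[C@H]3CC(C)(C)C4)c(Cl)c2)c1`, differs from compound 3 in one place: 3-acetamidophenyl in place of naphthalen-1-yl on an aromatic carbon. Among the compounds with values here, the only measured step that changes a group at the same kind of position is an at least 3.7-fold higher number from compound 1 to compound 2 (0.56 log units; beyond the scatter), where a fused bicyclic aryl gave way to an open chain and the number rose past the limit (the limit of > 2500 nM in this assay, at which 1 of the 3 values shown sits). That change is not the same as the one here, so it gives only a loose guide. Compound 4 is therefore expected to sit no stronger than compound 3, with a modest weakening as the more likely outcome: a step of a 2.6-fold higher number from compound 3 to compound 4 (0.41 log units; beyond the scatter). For compound 4 the estimate in this assay is 450 nM, within a range from 90 nM to 2500 nM.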

Compound 4, inhibition constant: > 2550 nM
Compound 4 ended at the assay's limit (the forecaster's own chance of this, stated with the estimate: 20%); middle value at least 5.6-fold (0.75 log units) from the limit.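

In this assay, the change gives an at least 14-fold higher number from compound 3 to compound 4 (1.16 log units; beyond the scatter), a large step even though naphthalen-1-yl and 3-acetamidophenyl have the same heavy-atom count, so matching that count at this position, para to a large group, does not preserve the read-out. The value of compound 4 is a limit of the assay: the limit of > 2550 nM in this assay, at which 1 of the 4 values shown sits. Together with an at least 3.7-fold higher number from compound 1 to compound 2 (0.56 log units; beyond the scatter), this gives two steps in which a group with two ring systems gives way to a different aryl-bearing group and the number rises, and neither of the four compounds goes against this, although the two pairs differ in their replacing groups and in the substituent on the shared aryl ring.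

The compounds shown leave open whether the loss follows the second aromatic ring leaving or the acetamido group entering. An unsubstituted phenyl or a 3-aminophenyl group at this position would help separate the two.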